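Chloro in place of nitro: notes on the series

The compounds below may be only part of what the source reports. "The series", "measured", "known", "first", "only" and "open" are said of these compounds alone.

Of the compounds shown here, three on a shared core have been measured so far. In a functional assay on BV-2 cells (Mus musculus), read by Griess assay, with a stated time of 24 h (on this read-out higher numbers stand for weaker inhibition and lower numbers for stronger inhibition), compound 1 `O=C1C=CC2(C=C1)OCC(Cc1ccccc1)C(=O)N2c1ccccc1` gives 570 nM as the reference value. In this assay compound 2 `O=C1C=CC2(C=C1)OCC(Cc1cc(C(F)(F)F)cc(C(F)(F)F)c1)C(=O)N2c1ccccc1` gives 70 nM and compound 3 `O=C1C=CC2(C=C1)OCC(Cc1cc(C(F)(F)F)ccc1[N+](=O)[O-])C(=O)N2c1ccccc1` gives 970 nM on the same read-out. The numbers of compound 3 and compound 1 lie within the scatter of each other, while compound 2 lies beyond the scatter from compound 3 on the side of stronger inhibition.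

Compound 4 `O=C1C=CC2(C=C1)OCC(Cc1cc(C(F)(F)F)ccc1Cl)C(=O)N2c1ccccc1` awaits measurement. Its difference from compound 3 (chloro in place of nitro on an aromatic carbon) is chloro in place of nitro on an aromatic carbon, ortho to a large group and para to a trifluoromethyl group. For the measured compounds named here, no measured pair isolates this exchange, and the expectation rests on indirect evidence. Compound 2 at 70 nM shows that a trifluoromethyl-bearing compound in this series can reach a low number, whereas compound 3 at 970 nM carries the nitro group that is leaving. The expected change is a 3.2-fold lower number from compound 3 to compound 4 (0.51 log units; beyond the scatter) toward stronger inhibition, a modest step that may only just clear the scatter. The estimate for compound 4 is 300 nM in this assay with an expected range from 90 nM to 900 nM on measurement.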

Compound 4, half-maximal inhibitory concentration: 770 nM
For compound 4 the middle estimate is 2.6-fold (0.41 log units) below the measured one; the measured number falls inside the stated range.
By their numbers in this assay, from the lowest: compound 2; then compounds 1, 4 and 3 (each within the scatter of the next).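

In this assay, for the compounds shown here, chloro in place of nitro gives a 1.3-fold lower number from compound 3 to compound 4 (0.10 log units; within the scatter), the first step that isolates a single exchange. At this aromatic carbon, ortho to a large group and para to a trifluoromethyl group, the nitro group with its 3 heavy atoms and 2 hydrogen-bond acceptors gives way to chloro with 1 heavy atom and no hydrogen-bond acceptor, and the step stays within the scatter, so this read-out does not separate the two groups at this position. No measurement on hand offers an explanation for this step, which stands as an observation only.

Still open, as far as these compounds go, is whether this position separates any groups at all, which an amine, a nitrile, a methoxy group or plain hydrogen at the same aromatic carbon would help to settle. Also open, from the compounds shown here alone, is whether chloro in place of nitro gives a step of similar size when the rest of the compound carries other groups on the shared core.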